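This account rests on a few compounds, and the source may have more. Where it says the series, first, only, none or still open, it means among the compounds named here.

Compound 1 `FC(F)(F)c1ccc(-c2ccc(-c3ccc(-c4nc5ccccc5[nH]4)cc3)cc2)cc1` gives 36600 nM
Compound 2 `CN(C)c1ccc(-c2ccc(-c3ccc(-c4nc5ccccc5[nH]4)cc3)cc2)cc1` gives 30100 nM

In a functional assay on A549 cells (Homo sapiens) for inhibition, read by sulforhodamine B assay (a higher number here means a weaker inhibitor of growth, a lower number a stronger inhibitor of growth), compound 2 gives 30100 nM and stands level with compound 1 within the scatter. Compound 3 `Clc1cccc(-c2ccc(-c3ccc(-c4nc5ccccc5[nH]4)cc3)cc2)c1` has 3-chlorophenyl in place of 4-(dimethylamino)phenyl on an aromatic carbon, para to a large group: 3-chlorophenyl in place of 4-(dimethylamino)phenyl on an aromatic carbon. Among the compounds with values here, the only measured step is a 1.2-fold lower number from compound 1 to compound 2 (0.08 log units; within the scatter) and it lies within the scatter. That step exchanged trifluoromethyl for dimethylamino, so it bears on this larger change only in part. No step beyond the scatter is therefore expected in this assay and no direction is favoured. The estimated step is a 1.0-fold lower number from compound 2 to compound 3 (0.00 log units; within the scatter) and remains a working expectation. For compound 3 the expected value is 30000 nM with an estimated range of 12000 nM to 65000 nM for now.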

Compound 3, concentration for 50% growth inhibition: 31100 nM
Compound 3: middle estimate off by 1.0-fold (0.02 log units), on the low side; the range from low to high includes it.
By their numbers in this assay, from the lowest: compounds 2, 3 and 1 (each within the scatter of the next).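

In this assay, the position on the aromatic carbon para to a large group now also tolerates a 3-chlorophenyl, with a 1.0-fold higher number from compound 2 to compound 3 (0.01 log units; within the scatter) and a 1.2-fold lower number from compound 1 to compound 3 (0.07 log units; within the scatter). All three compounds therefore stand level within the scatter, even though the entering ring carries its substituent at a different ring position from the two 4-substituted phenyls. No measurement bearing on this flat result is available. Open, from the compounds shown here alone, is whether a carboxylic acid or a primary amine on this ring would shift the number. Also open, going by these compounds, is whether replacing the phenyl ring with piperidine would do so.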